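Bromo to 4-acetylphenyl on the shared core

This account rests on a few compounds, and the source may have more. Where it says the series, first, only, none or still open, it means among the compounds named here.

In a functional assay on KYSE-410 cells (Homo sapiens) for antiproliferative activity, read by MTT assay, with a stated time of 72 h (a lower number here means a stronger inhibitor, a higher number a weaker inhibitor), compound 2 `O=C(Nc1cccc(F)c1)c1cc(=O)[nH]c2cc(Br)ccc12` gives 7300 nM. Compound 1 `O=C(Nc1ccccn1)c1cc(=O)[nH]c2cc(Br)ccc12` gives 9800 nM, and compound 3 `O=C(Nc1cc(F)cc(F)c1)c1cc(=O)[nH]c2cc(Br)ccc12` gives 11200 nM. Compound 2 cannot be separated from either neighbour. The pyridin-2-yl to 3-fluorophenyl exchange is a 1.3-fold lower number from compound 1 to compound 2 (0.13 log units; within the scatter), and the added fluoro is a 1.5-fold higher number from compound 2 to compound 3 (0.19 log units; within the scatter).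

Compound 4 `CC(=O)c1ccc(-c2ccc3c(C(=O)Nc4cccc(F)c4)cc(=O)[nH]c3c2)cc1` carries 4-acetylphenyl in place of bromo on an aromatic carbon. Both measured steps concern the amide-side aryl group, and all three measured compounds keep the bromo. Among the measured compounds shown here, no measured step therefore tests this position, and the data give no firm direction. The entering group is much larger than the changes made so far, so a step beyond the scatter is plausible, and a lower number is tentatively favoured in this assay. The expected size is a 2.1-fold lower number from compound 2 to compound 4 (0.32 log units; beyond the scatter), though a result within the scatter remains possible. For compound 4 the estimated value is 3500 nM, with an expected range of 800 nM to 15000 nM.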

Compound 4, half-maximal inhibitory concentration: > 20000 nM
Compound 4: no number, only a limit; the forecaster's own chance of this, stated with the estimate: 10%; at least 5.7-fold (0.75 log units) between middle value and limit.
By their numbers in this assay, from the lowest: compounds 2, 1 and 3 (each within the scatter of the next). At a limit, above all of these: compound 4.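

Notes on the bromo position: 4-acetylphenyl in place of bromo gives an at least 2.7-fold higher number from compound 2 to compound 4 (0.43 log units; beyond the scatter), the only step shown that lies beyond the scatter in this assay. The aromatic carbon bearing bromo therefore responds to substitution, whereas the amide-side changes among compounds 1, 2 and 3 stayed within the scatter, and this one replacement gives no gain over bromo. The reading for compound 4 is a limit and not a number, so the step has a lower bound but no measured size: the limit of > 20000 nM in this assay, at which 1 of the 4 values shown sits.

The compounds shown do not separate the effect of the added aromatic ring from that of its acetyl group, so an unsubstituted phenyl or a 4-aminophenyl at this carbon would be informative. From the compounds shown here alone, whether any replacement of bromo here can give a lower number than compound 2 remains open.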